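Replacing one side group on the core of compound 1

The compounds below may be only part of what the source reports. "The series", "measured", "known", "first", "only" and "open" are said of these compounds alone.

Compound 1 `CC(C)NC(=O)CC(c1ccc(-c2ccc3cccc(F)c3c2)[nH]c1=O)C(C)C` — 15 nM
Compound 2 `CCn1ncc2c(F)cc(-c3ccc(C(CC)(CC)c4nnc(C)[nH]4)c(=O)[nH]3)cc21` — 90 nM
Compound 3 `CCn1ncc2c(F)cc(-c3ccc(C(CC)(CC)c4ncn(C)n4)c(=O)[nH]3)cc21` — 96 nM

In a functional assay on CHO cells for antagonist activity at prostaglandin E2 receptor EP3 subtype (Homo sapiens), read by cAMP accumulation (a higher number here means a weaker inhibitor, a lower number a stronger inhibitor), compound 1 gives the lowest of the three numbers; compound 2 stands beyond the scatter above it, and compound 3 a little further still. Compound 4 `CC(C)C(c1ccc(-c2ccc3cccc(F)c3c2)[nH]c1=O)N1CCN/C1=N\C#N` keeps the core of compound 1 and differs in one side group only: a group of 8 heavy atoms (4 carbon, 4 nitrogen; one five-membered non-aromatic ring with 2 hetero atoms) in place of a group of 7 heavy atoms (5 carbon, 1 nitrogen, 1 oxygen; no ring), on a saturated chain carbon bound to an aromatic carbon and a saturated chain carbon. Among the compounds with values here, the single measured step, a 1.1-fold higher number from compound 2 to compound 3 (0.03 log units; within the scatter), exchanges one heteroaromatic ring for another on a different core and lies within the scatter, so it says little about the present change. Within the data shown here, no measured pair mirrors it. The number for compound 4 is therefore expected to stay close to that of its parent, at 30 nM, within 8 nM to 120 nM. That estimate means an expected step of a 2.0-fold higher number from compound 1 to compound 4 (0.30 log units; within the scatter).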

Compound 4, half-maximal inhibitory concentration: 38 nM
Compound 4: middle estimate off by 1.3-fold (0.10 log units), on the low side, and the stated range covers the measured number.
By their numbers in this assay, from the lowest: compound 1; then compound 4; then compounds 2 and 3 (each within the scatter of the next).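

Swapping the side group on this saturated chain carbon changes it almost entirely, yet in this assay the number rises only modestly, a 2.5-fold higher number from compound 1 to compound 4 (0.40 log units; beyond the scatter). The group that enters holds no oxygen, so a number in this range does not depend on an oxygen in this side group. Nothing measured here explains the rise.

On these data alone, whether a carboxylic acid or a simple amine on the same carbon would keep the number this low remains open. So does which part of the entering ring accounts for the step.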